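The source may report more compounds than this note shows. Statements on the series, on what has been measured and on what is new or still open speak of the compounds shown alone.

Compound 1 (`OC[C@H](NC[C@H]1NC[C@H](O)[C@@H]1O)c1ccc(-c2ccccc2)cc1`) was tested in a functional assay on MDA-MB-231 cells (Homo sapiens) for cytotoxicity, read by colorimetric assay, with a stated time of 72 h; a lower number here means a stronger inhibitor, a higher number a weaker inhibitor. In this assay compound 1 gives > 200000 nM, which is a limit of the assay rather than a measured number. Compound 2 (`OC[C@H](NC[C@H]1NC[C@H](O)[C@@H]1O)c1ccc(-c2ccc(C(F)(F)F)cc2)cc1`), which carries a trifluoromethyl on the outer ring, gives 66000 nM in this assay. Among the compounds with values here, the single measured step, an at least 3.0-fold lower number from compound 1 to compound 2 (0.48 log units; beyond the scatter), is the only comparison available, and its size can only be stated as a lower bound because of the limit of > 200000 nM in this assay, at which 1 of the 2 values shown sits. Compound 3 (`OC[C@H](NC[C@H]1NC[C@H](O)[C@@H]1O)c1ccc(-c2ccsc2)cc1`) differs from compound 1 in a different way: thiophen-3-yl in place of phenyl on an aromatic carbon. Within the data shown here, no measured step follows this kind of exchange of one aromatic ring for another, so the trifluoromethyl step offers no direct guide; it shows only that altering the outer ring can move the number by at least a modest amount. With compound 1 standing at a limit, the estimate for compound 3 is 150000 nM, with a range from 40000 nM to 400000 nM. This estimate means a step of an at least 1.3-fold lower number from compound 1 to compound 3 (0.12 log units; that floor lies within the scatter), expected to stay within the scatter, with a fair chance that this assay again reports only a limit for compound 3.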

Compound 3, half-maximal inhibitory concentration: "not active" (no number reported)
For compound 3 the study gives words and no number; there is nothing to compare the estimate with.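

Compound 3 is reported in this assay only in words, as "not active", so no new step can be read from compound 1 to compound 3. The compounds shown leave open whether thiophen-3-yl in place of phenyl moves the number at all, and the comparison is further narrowed by a limit: the limit of > 200000 nM in this assay, at which 1 of the 3 values shown sits.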